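Compound 4: a Hydroxy-Methoxy Phenyl Variant of Compound 3

The source may report more compounds than this note shows. Statements on the series, on what has been measured and on what is new or still open speak of the compounds shown alone.

Three analogues sharing one core have been examined in a functional assay on the whole organism (Hindlimb, strain albino) with Mus musculus as the target, in the maximal electroshock model, with a stated time of 0.5 h; a lower number here means that less compound is needed, a higher number that more compound is needed for the effect. Compound 1 `COc1ccc(C2CC(Nc3nc4ccc(Cl)cc4s3)=NN2C(C)=O)cc1` gives 93.3 umol/kg. Compound 2 `CC(=O)N1N=C(Nc2nc3ccc(Cl)cc3s2)CC1OC1=CC=C1` gives 212 umol/kg. Compound 3 `CC(=O)N1N=C(Nc2nc3ccc(Cl)cc3s2)CC1c1ccccc1` gives 161 umol/kg, the second highest of the three numbers, within the scatter of both compound 2 and compound 1. Compound 4 `COc1ccc(C2CC(Nc3nc4ccc(Cl)cc4s3)=NN2C(C)=O)cc1O` differs from compound 3 in one place: 3-hydroxy-4-methoxyphenyl in place of phenyl on a saturated ring carbon. For the measured compounds named here, the only measured step bearing on this change is the one in which hydrogen stands in place of methoxy, a 1.7-fold higher number from compound 1 to compound 3 (0.24 log units; within the scatter), a step within the scatter. Compound 4 restores that methoxy and adds a hydroxy, so a small decrease at most is expected, a 1.4-fold lower number from compound 3 to compound 4 (0.15 log units; within the scatter). Compound 4 is thus expected to give 115 umol/kg, between 50 umol/kg and 260 umol/kg.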

Compound 4, dose for half-maximal effect: 127 umol/kg
Beside the measured number, compound 4's estimate is 1.1-fold (0.04 log units) below it, and the stated range covers the measured number.
By their numbers in this assay, from the lowest: compounds 1, 4, 3 and 2 (each within the scatter of the next, the first and the last beyond it).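

Placing 3-hydroxy-4-methoxyphenyl on the saturated ring carbon keeps the number in this assay within the scatter of phenyl (a 1.3-fold lower number from compound 3 to compound 4 (0.10 log units; within the scatter)) and of the four-membered ring group of compound 2 (a 1.7-fold lower number from compound 2 to compound 4 (0.22 log units; within the scatter)). The hydroxy is the first one on this aromatic ring among these compounds, and it also stays within the scatter (a 1.4-fold higher number from compound 1 to compound 4 (0.13 log units; within the scatter)). No evidence is available to explain these results. From the compounds shown here alone, whether an amine or a carboxylic acid on this aromatic ring would move the number beyond the scatter remains open.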